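From a limit toward a measurable growth inhibition

The source may hold more compounds than are shown below. What is called first, only, known or untested is meant among the compounds shown, and "the series" means these compounds.

In a functional assay on U-251 cells (Homo sapiens) for inhibition, read by sulforhodamine B assay, with a stated time of 48 h (a higher number here means a weaker inhibitor of growth, a lower number a stronger inhibitor of growth), compound 1 `O=C(Nc1cccc(-n2cc(-c3ccncc3)c(-c3ccc(Cl)c(O)c3)n2)c1)Nc1cccc(C(F)(F)F)c1` gives a measured number, 7650 nM in this series. Compound 2 `COc1cc(-c2nn(-c3cccc(NC(=O)c4cccc(C(F)(F)F)c4)c3)cc2-c2ccncc2)ccc1Cl` stands only at a limit of the assay, > 50000 nM here, and has no exact number.

Compound 3 `COc1cc(-c2nn(-c3cccc(NC(=O)Nc4ccc(Cl)c(C(F)(F)F)c4)c3)cc2-c2ccncc2)ccc1Cl` differs from compound 2 in one place: (4-chloro-3-(trifluoromethyl)phenyl)amino in place of 3-(trifluoromethyl)phenyl on a carbonyl carbon with (4-chloro-3-(trifluoromethyl)phenyl)amino in place of 3-(trifluoromethyl)phenyl on a carbonyl carbon. Among the compounds with values here, no measured step yet shows what this change does in this assay so the expectation leans on the only exact number available, compound 1 at 7650 nM in the same test. The expected step of an at least 5.5-fold lower number from compound 2 to compound 3 (0.74 log units; beyond the scatter) is large and toward stronger inhibition of growth, although a result at the limit remains possible. Compound 3 is estimated at 9000 nM with an expected range from 2500 nM to 35000 nM in this test.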

Compound 3, concentration for total growth inhibition: 4180 nM
The estimate for compound 3 lay 2.2-fold (0.33 log units) above the measured number; low and high end bracket the measured number.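

In this assay the swap on the carbonyl carbon produces an at least 11-fold lower number from compound 2 to compound 3 (1.07 log units; beyond the scatter) and gives this pair a measured number in place of a limit. Within the data shown here, this is the first sign that this position matters: (4-chloro-3-(trifluoromethyl)phenyl)amino in place of 3-(trifluoromethyl)phenyl brings one nitrogen, one chlorine and one hydrogen-bond donor, and it goes with stronger inhibition of growth. Going by these compounds, the true size of the step stays unknown because compound 2 stands at a limit of the test: the limit of > 50000 nM in this assay, at which 1 of the 3 values shown sits.

The swap adds the amino nitrogen and the chlorine together, and the compounds shown do not separate the two. On these data alone, it also remains open whether a fluorine or a methyl group in place of that chlorine would give a similar number.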